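The source may hold more compounds than are shown below. What is called first, only, known or untested is meant among the compounds shown, and "the series" means these compounds.

Of the compounds shown here, three share one core and have been tested in a functional assay on CHO.K1 cells for antagonist activity at prostaglandin D2 receptor 2 (Homo sapiens), read by GTPgammaS binding, with a stated time of 1 h; on this read-out higher numbers stand for weaker inhibition and lower numbers for stronger inhibition. Compound 1 `Cc1c(Cc2cc(F)ccc2S(=O)(=O)c2ccccc2)c2c(n1CC(=O)O)CCNC2=O` gives 3.7 nM. Compound 2 `Cc1c(Cc2ccccc2S(=O)(=O)c2ccc(F)cc2)c2c(n1CC(=O)O)CCNC2=O` gives 3.3 nM, and this number and that of compound 1 lie within the usual scatter of each other. Within the data shown here, compound 3 `COc1ccc(S(=O)(=O)c2ccc(F)cc2)c(Cc2c3c(n(CC(=O)O)c2C)CCNC3=O)c1` gives 7.1 nM, and the step of a 2.2-fold higher number from compound 2 to compound 3 (0.33 log units; beyond the scatter) is the only measured change that sits beyond the scatter.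

Compound 4 `Cc1c(Cc2ccccc2S(=O)(=O)N2CCOCC2)c2c(n1CC(=O)O)CCNC2=O` has not been measured. It differs from compound 2 by morpholin-4-yl in place of 4-fluorophenyl on a sulfonyl sulfur. Among the measured compounds shown here, none of the measured steps touches this position: the step from compound 2 to compound 3 concerns a methoxy on an aromatic carbon, and compounds 1 and 2 differ only in where a fluorine sits. So the measured data give no direct guide, and the exchange of an aromatic ring for a non-aromatic ring is the largest change in this series. The expectation is a moderate rise in number, a 4.5-fold higher number from compound 2 to compound 4 (0.66 log units; beyond the scatter), with wide uncertainty. Compound 4 is therefore estimated at 15 nM, between 4 nM and 60 nM.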

Compound 4, half-maximal inhibitory concentration: 22 nM
Compound 4: the middle estimate sits 1.5-fold (0.17 log units) below what was measured, and the stated range covers the measured number.
By their numbers in this assay, from the lowest: compounds 2, 1 and 3 (each within the scatter of the next, the first and the last beyond it); then compound 4.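

Exchanging 4-fluorophenyl for morpholin-4-yl on the sulfonyl sulfur gives a 6.7-fold higher number from compound 2 to compound 4 (0.82 log units; beyond the scatter) in this assay, so the number at this position does respond to the group placed there. An aromatic ring at this place is still not needed for inhibition in the nanomolar range, since compound 4, with its non-aromatic ring, gives 22 nM in this assay. Nothing measured here accounts for the rise in number.

One exchange cannot separate the loss of the aromatic ring from the arrival of the ring oxygen and nitrogen. Piperidin-1-yl, which has no ring oxygen, or an open-chain dimethylamino group on the same sulfonyl sulfur would test these two parts apart, and how either would read remains open.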